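The source may report more compounds than this note shows. Statements on the series, on what has been measured and on what is new or still open speak of the compounds shown alone.

Working notes on the series, cytotoxicity.

Compound 1 `COc1cccc([C@H]2CC(C)(O)[C@@H]3CC[C@@H](C)C[C@H]3O2)c1OC` is one of two measured members. In an ADME assay on MDCK cells (Canis lupus familiaris) for cytotoxicity, read by MTT assay, with a stated time of 48 h (on this read-out higher numbers stand for lower toxicity in this test and lower numbers for higher toxicity in this test), compound 1 reaches only the limit of the test, > 937000 nM; this is a limit, not a number. Compound 2 `COc1ccc([C@H]2CC(C)(O)[C@@H]3CC[C@@H](C)C[C@H]3O2)c(OC)c1OC` likewise reaches only a limit in this assay, > 857000 nM. Since both values are limits, the step that the two limits leave unreadable from compound 1 to compound 2 cannot be read (the limit of > 857000 nM in this assay, at which 1 of the 2 values shown sits; (the limit of > 937000 nM in this assay, at which 1 of the 2 values shown sits)), so where compound 1 stands is known only as a floor.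

Compound 3 `COc1cccc([C@H]2CC(C)(F)[C@@H]3CC[C@@H](C)C[C@H]3O2)c1OC` differs from compound 1 by fluoro in place of hydroxy on a saturated ring carbon, in words fluoro in place of hydroxy on a saturated ring carbon. Among the compounds with values here, no measured step bears on such an exchange; the single step available is unreadable between two limits. The expectation for this assay is therefore no step beyond the scatter, with a number no higher from compound 1 to compound 3 (the limit leaves the size open) expected to be flat. Compound 3 is estimated at 930000 nM, range 300000 nM to 2000000 nM, most likely again as a limit.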

Compound 3, half-maximal cytotoxic concentration: 180000 nM
Beside the measured number, compound 3's estimate is 5.2-fold (0.71 log units) above it, and the stated range ends above it.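

Fluoro in place of hydroxy on a saturated ring carbon gives an at least 5.2-fold lower number from compound 1 to compound 3 (0.71 log units; beyond the scatter) in this assay, the first readable step in the series, since the step from compound 1 to compound 2 cannot be read. Within the data shown here, this ring carbon is therefore a place where a single exchange moves the read-out beyond the scatter, and compound 3 carries a measured number where the earlier compounds reach only limits. The true size of the step stays unknown because its starting point is a limit: the limit of > 937000 nM in this assay, at which 1 of the 3 values shown sits.

From the compounds shown here alone, whether the lower number follows from the loss of hydroxy or from the entry of fluoro remains open, and no measured property of either group is at hand. An amine, a chloro group or plain hydrogen at this ring carbon would help to separate the two.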